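Acetyl in Place of Ring Hydrogen: Compound 4 Predicted

The source may report more compounds than this note shows. Statements on the series, on what has been measured and on what is new or still open speak of the compounds shown alone.

Measured compounds:
compound 1, `O=C(CSc1nc2cccnc2[nH]1)Nc1cccc(Br)c1`: 23%
compound 2, `O=C(CSc1nc2cccnc2[nH]1)Nc1ccccc1`: 30%
compound 3, `O=C(CSc1nc2cccnc2[nH]1)Nc1ccc(Cl)cc1`: 17%

In an assay on isolated protein for inhibition of Ectonucleotide pyrophosphatase/phosphodiesterase family member 1 (Homo sapiens), tested at 10 uM (a lower number here means less inhibition, a higher number more inhibition at the concentration tested (going by the name of the read-out)), compound 2 shows the highest of the three numbers; compound 1 sits a number 7 percentage points higher from compound 1 to compound 2 (within the scatter), within the scatter, while compound 3 lies a number 13 percentage points lower from compound 2 to compound 3 (beyond the scatter), beyond it. Compound 4, `CC(=O)c1cccc(NC(=O)CSc2nc3cccnc3[nH]2)c1`, is not yet measured. It differs from compound 2 as follows: acetyl in place of hydrogen on an aromatic carbon. Going by the values given here, the steps that bear on this are the two substituent changes on the same ring: a number 7 percentage points higher from compound 1 to compound 2 (within the scatter) and a number 13 percentage points lower from compound 2 to compound 3 (beyond the scatter). Both show that a substituent on this ring gave a modest or smaller drop, yet neither involves an acetyl group, so the expected step is small. For compound 4 the estimated value is 25%, with a range of 10% to 42%, meaning an expected change of a number 5 percentage points lower from compound 2 to compound 4 (within the scatter).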

Compound 4, a percentage reported as inhibition, at one concentration (the size of the read-out at that concentration, not a potency): 50%
Estimate against measurement, compound 4: 25 percentage points below; measured number above the stated range.
By their numbers in this assay, from the lowest: compounds 3, 1 and 2 (each within the scatter of the next, the first and the last beyond it); then compound 4.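

In this assay this carbon, meta to a large group, turns out to accept a substituent that lifts the number: acetyl gives a number 20 percentage points higher from compound 2 to compound 4 (beyond the scatter) and no earlier substituent gave a rise beyond the scatter. The identity of the group matters at this place, since acetyl in place of bromo gives a number 27 percentage points higher from compound 1 to compound 4 (beyond the scatter) while compound 1 stays within the scatter of compound 2. No measurement available explains the rise.

As far as these compounds go, whether the gain is special to acetyl stays open: an amine, a methoxy group or a carboxylic acid on this carbon could match it or fall short.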